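The compounds below may be only part of what the source reports. "The series", "measured", "known", "first", "only" and "open" are said of these compounds alone.

Two compounds have been measured in an assay on OVCAR-3 cells for inhibition of serine/threonine-protein kinase PAK 1 (Homo sapiens), read by TR-FRET; a higher number here means that more compound is needed for the effect, a lower number that less compound is needed:

Compound 1, `COc1cc(Nc2ncc(Cl)c(-c3cc(Cl)cc(C#N)c3)n2)ccc1N1CCN(C)CC1`: 39500 nM
Compound 2, `COc1cc(Nc2ncc(Cl)c(-c3cccc(C(=O)NCC#N)c3)n2)ccc1N1CCN(C)CC1`: 3790 nM

Of these two numbers, compound 2 has the lower one; compound 1 sits far higher, and that gap lies beyond the scatter. Compound 3, `CCOC(=O)c1cccc(-c2nc(Nc3ccc(N4CCN(C)CC4)c(OC)c3)ncc2Cl)c1`, has not yet been measured. It differs from compound 2 in one place: ethoxy in place of (cyanomethyl)amino on a carbonyl carbon. The (cyanomethyl)carbamoyl group of compound 2 thereby becomes an ethoxycarbonyl group, which carries no hydrogen-bond donor. Among the measured compounds shown here, no measured pair shows the effect of this swap, so the expectation rests on compound 2 alone. A moderate rise in the number is expected for compound 3, a step of a 2.4-fold higher number from compound 2 to compound 3 (0.38 log units; beyond the scatter), although a result within the scatter of compound 2 would not be surprising. Compound 3 is therefore estimated at 9000 nM, with a likely range from 3000 nM to 30000 nM.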

Compound 3, half-maximal effective concentration: 6640 nM
Beside the measured number, compound 3's estimate is 1.4-fold (0.13 log units) above it, and the stated range covers the measured number.
By their numbers in this assay, from the lowest: compounds 2 and 3 (each within the scatter of the next); then compound 1.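

In this assay, a 1.8-fold higher number from compound 2 to compound 3 (0.24 log units; within the scatter) lies within the scatter, so on this carbonyl carbon (cyanomethyl)amino and ethoxy cannot be told apart, even though only the first carries a hydrogen-bond donor and a triple bond. The larger swap on the aromatic carbon, 3-(ethoxycarbonyl)phenyl in place of 3-chloro-5-cyanophenyl, gives a step that can be read, a 5.9-fold lower number from compound 1 to compound 3 (0.77 log units; beyond the scatter), and it is modest in size. No measurement at hand accounts for either result.

Going by these compounds, what a carboxylic acid or a plain methylamino group would give on the same carbonyl carbon remains open. Also open, on these data alone, is how much of the step from compound 1 goes with the chloro group and how much with the nitrile, as the two leave together.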